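Benzimidazole-imidazopyrazine series: formyl in place of methyl

The source may hold more compounds than are shown below. What is called first, only, known or untested is meant among the compounds shown, and "the series" means these compounds.

Measured so far:
compound 1 `O=Cc1ccc(-c2cn3ccnc3c(-c3ccc4ncn(C5CCCCC5)c4c3)n2)cc1` — 45.5%
compound 2 `CCc1ccc(-c2cn3ccnc3c(-c3ccc4ncn(Cc5ccccc5)c4c3)n2)cc1` — 21.8%
compound 3 `Cc1cccc(-c2cn3ccnc3c(-c3ccc4ncn(Cc5ccccc5)c4c3)n2)c1` — 8.47%

In a functional assay on Hs-578T cells (Homo sapiens) for inhibition, read by sulforhodamine B assay, with a stated time of 48 h, tested at 10 uM (on this read-out lower numbers stand for less inhibition and higher numbers for more inhibition at the one concentration tested (going by the name of the read-out)), compound 3 stands lowest of the three numbers; its nearest neighbour is compound 2, and the furthest is compound 1. Among the compounds with values here, the one measured step that touches the same position, a number 13.3 percentage points lower from compound 2 to compound 3 (beyond the scatter), shows that changing the aryl group at this carbon moves the read-out beyond the scatter.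

Compound 4 `O=Cc1ccc(-c2cn3ccnc3c(-c3ccc4ncn(Cc5ccccc5)c4c3)n2)cc1` differs from compound 3 in that place: 4-formylphenyl in place of 3-methylphenyl on an aromatic carbon. Within the data shown here, the group that enters is the one carried by compound 1, which differs from compound 4 elsewhere in the molecule; compound 1 gives 45.5% in this assay, while compound 3 gives 8.47%. Among the measured compounds shown here, no step between compounds with this exact change is available, so the expectation rests on those two values and on the step from compound 2 to compound 3. An increase beyond the scatter is expected, estimated as a number 21.5 percentage points higher from compound 3 to compound 4 (beyond the scatter). Compound 4 is estimated at 30%, with a range from 12% to 50%.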

Compound 4, a percentage reported as inhibition, at one concentration (the size of the read-out at that concentration, not a potency): 45.5%
For compound 4 the middle estimate is 15.5 percentage points below the measured one; low and high end bracket the measured number.
By their numbers in this assay, from the lowest: compound 3; then compound 2; then compounds 1 and 4 (each within the scatter of the next).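

In this assay the group on this aromatic carbon can move the read-out much further than the earlier step showed: 4-formylphenyl in place of 3-methylphenyl gives a number 37 percentage points higher from compound 3 to compound 4 (beyond the scatter) and formyl in place of ethyl gives a number 23.7 percentage points higher from compound 2 to compound 4 (beyond the scatter) on the shared core. With 4-formylphenyl held constant, benzyl in place of cyclohexyl on the aromatic nitrogen gives no change at the digits printed from compound 1 to compound 4 (within the scatter) and so leaves the read-out unmoved in this pair. Nothing available bears on why the formyl compounds differ from the alkyl compounds.

On these data alone, whether the formyl group itself is needed stays open, and a hydroxymethyl group, a carboxylic acid or an amine in its place would address that. Also open, as far as these compounds go, is whether benzyl and cyclohexyl still match when 4-ethylphenyl or 3-methylphenyl occupies the aromatic carbon.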